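A Hydroxy Group Added to Compound 3

A few compounds are considered here, and "the series" means these few. Any claim that something is new, unique, unknown or untested is made for them only; others in the source may bear on it.

Compound 1 `CC(=O)NC1C2CC3CC1CC(C2)C31OO[C@]2(CC[C@@H](c3ccc(OCC(=O)O)cc3)CC2)O1`: < 7 mL.min-1.g-1 (a limit)
Compound 2 `O=C(O)COc1ccc([C@H]2CC[C@]3(CC2)OOC2(O3)C3CC4CC(C3)CC2C4)cc1Cl`: 8 mL.min-1.g-1
Compound 3 `O=C(O)c1cccc([C@H]2CC[C@]3(CC2)OOC2(O3)C3CC4CC(C3)CC2C4)c1`: 30 mL.min-1.g-1

All three compounds were tested in an ADME assay on microsomes from liver (Mus musculus) for metabolic stability, using NADPH, with a stated time of 60 min, in the presence of a further agent that is not named here; on this read-out higher numbers stand for fast clearance and lower numbers for slow clearance. Compound 1 gives < 7 mL.min-1.g-1, which is a limit of the assay and not a number. Of the two true numbers, compound 3 holds the higher at 30 mL.min-1.g-1. Compound 2 stands at 8 mL.min-1.g-1, and the gap between the two lies beyond the usual scatter.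

The next compound, compound 4 `O=C(O)c1cc([C@H]2CC[C@]3(CC2)OOC2(O3)C3CC4CC(C3)CC2C4)ccc1O`, keeps the core of compound 3 and its carboxy group. The change is hydroxy in place of hydrogen on an aromatic carbon, ortho to a carboxy group and para to a large group.

Among the measured compounds shown here, no measured pair in this small set isolates such a change, so any forecast is tentative. For the measured compounds named here, it rests on the position of compound 3 at 30 mL.min-1.g-1, the highest number so far, which leaves more room for a fall than for a rise. A modest fall is therefore expected, close to the edge of the scatter, and the expected step is a 2.1-fold lower number from compound 3 to compound 4 (0.33 log units; beyond the scatter). In this assay, compound 4 is estimated at 14 mL.min-1.g-1, with an expected range of 7 mL.min-1.g-1 to 32 mL.min-1.g-1.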

Compound 4, intrinsic clearance in microsomes in the Mus musculus assay: 20 mL.min-1.g-1
The estimate for compound 4 lay 1.4-fold (0.15 log units) below the measured number, within the range that was stated.
By their numbers in the Mus musculus assay, from the lowest: compound 2; then compounds 4 and 3 (each within the scatter of the next). At a limit, below all of these: compound 1.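

In the Mus musculus assay, hydroxy in place of hydrogen on an aromatic carbon, ortho to a carboxy group and para to a large group, gives a 1.5-fold lower number from compound 3 to compound 4 (0.18 log units; within the scatter). Among the compounds shown here, the earlier compounds offered no pair that differs in one place, so this is the first direct reading of a single change in this set, and it shows that a hydroxy group at this place brings no difference that can be told from the scatter. In a physicochemical assay for solubility, read by nephelometry, in phosphate buffer, measured as kinetic solubility, with a stated time of 30 min, at pH 6.5 (a lower number here means a less soluble compound, a higher number a more soluble compound), compound 3 gives < 1.6 ug/mL, which is a limit of the assay and not a number. In the physicochemical assay compound 4 gives < 1.6 ug/mL, which is also a limit of the assay and not a number. In the physicochemical assay, the step from compound 3 to compound 4 cannot be read, and each of the two values is a limit of the assay and not a number: the limit of < 1.6 ug/mL in the physicochemical assay, at which 2 of the 2 values shown sit.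

Going by these compounds, whether a different group at this same place, such as an amine or a methoxy group, would give a step beyond the scatter in the Mus musculus assay remains open, as does whether the hydroxy group would give the same step on a compound with a longer chain carrying the carboxy group. On these data alone, it also remains open whether any such group would bring a compound on this core to a true number in the physicochemical assay.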